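Series notes: amide nitrogen substituent in phenoxyacetamides

The source may report more compounds than this note shows. Statements on the series, on what has been measured and on what is new or still open speak of the compounds shown alone.

Measured compounds:
compound 1 `CCN(Cc1cccs1)C(=O)COc1ccc(F)cc1` — 422 nM
compound 2 `Cc1ccc(OCC(=O)N(Cc2cccs2)C2CCCCC2)cc1` — 40000 nM
compound 3 `CCN(Cc1cc[nH]c1)C(=O)COc1ccc(C)cc1` — 21800 nM

Read-out is an assay on HEK293 cells for agonist activity at transient receptor potential cation channel subfamily M member 8 (Homo sapiens), read by fluorescence and calcium flux, with a stated time of 15 min; a higher number here means that more compound is needed for the effect, a lower number that less compound is needed. Compound 2 carries the highest number of the three. Its gap to compound 3 lies within the usual scatter, so no order between compound 2 and compound 3 is claimed. Its gap to compound 1 lies beyond the scatter: compound 1, with an ethyl group on the amide nitrogen and a fluoro group on the phenoxy ring, needs far less compound for the effect than compound 2 with its cyclohexyl group.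

Compound 4 `Cc1ccc(OCC(=O)N(Cc2cccs2)c2c(C)n[nH]c2C)cc1` is not yet measured. It differs from compound 2 in one place: 3,5-dimethyl-1H-pyrazol-4-yl in place of cyclohexyl on an amide-type nitrogen. Within the data shown here, no step between measured compounds follows this change, so the direction rests on the pattern that the only compound with a small nitrogen substituent and a thienylmethyl group sits far below compound 2, since compound 1 stands at 422 nM; compound 3, also with an ethyl group, goes against this, sitting high at 21800 nM.

For compound 4 a step of a 1.6-fold lower number from compound 2 to compound 4 (0.20 log units; within the scatter) is expected, toward a somewhat lower number but not beyond the scatter with confidence. Compound 4 is estimated at 25000 nM, with a range from 6000 nM to 80000 nM.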

Compound 4, half-maximal effective concentration: 0.3 nM
Compound 4: the middle estimate sits 83000-fold (4.92 log units) above what was measured, and the stated range ends above it.
By their numbers in this assay, from the lowest: compound 4; then compound 1; then compounds 3 and 2 (each within the scatter of the next).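

In this assay the substituent on the amide-type nitrogen, whose other neighbours are the carbonyl carbon and a saturated chain carbon, proves to be a highly sensitive position: 3,5-dimethyl-1H-pyrazol-4-yl in place of cyclohexyl gives a 130000-fold lower number from compound 2 to compound 4 (5.12 log units; beyond the scatter) with the rest of the structure unchanged. The earlier compounds shown here differ in more than one place and so could not isolate this position; this single change now shows that it can move the number far beyond the scatter. The change exchanges a six-membered non-aromatic ring of carbon only, with no hydrogen-bond donors or acceptors, for a five-membered aromatic ring with 2 hetero atoms, 1 hydrogen-bond donor and 1 hydrogen-bond acceptor, but no measurement here bears on which of these differences accounts for the step.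

From the compounds shown here alone, it remains open whether the step depends on the two methyl groups, the ring nitrogens or the aromatic ring itself, which a pyrazol-4-yl group without the methyl groups or a phenyl group at the same position would help to separate. Going by these compounds, it is also open whether 3,5-dimethyl-1H-pyrazol-4-yl gives a similar step alongside the fluoro group on the phenoxy ring of the core of compound 1.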